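A few compounds are considered here, and "the series" means these few. Any claim that something is new, unique, unknown or untested is made for them only; others in the source may bear on it.

In a functional assay on HepG2 cells (Homo sapiens) for antiproliferative activity, read by MTT assay, with a stated time of 72 h (on this read-out lower numbers stand for stronger inhibition and higher numbers for weaker inhibition), compound 1 `COc1ccc(N2C(=O)COc3ccc(-c4cnc5ccccc5c4)cc32)cc1` gives only a limit, > 40000 nM. Compound 2 `O=C1COc2ccc(-c3cccc(NS(=O)(=O)c4ccc(F)cc4)c3)cc2N1c1ccccc1`, which carries a different aromatic substituent on the shared core, is measured in this assay at 30300 nM. Both numbers together show that the measured pair sits at the weak end of the scale. Compound 1 stands at the limit of > 40000 nM in this assay, at which 1 of the 2 values shown sits, and its position is known only that far. Compound 3 `O=C1COc2ccc(-c3cnc4ccccc4c3)cc2N1c1ccc(Cl)cc1` differs from compound 1 by a single change: chloro in place of methoxy on an aromatic carbon. Within the data shown here, no step between two measured compounds is available to calibrate this exchange, and nothing among the numbers points in either direction. The step expected for this change is a number no higher from compound 1 to compound 3 (the limit leaves the size open), none beyond the usual scatter. Compound 3 is therefore expected to give about 40000 nM, in a range from 15000 nM to 100000 nM, with a real chance that this assay again reports only a limit.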

Compound 3, half-maximal inhibitory concentration: 32700 nM
For compound 3 the middle estimate is 1.2-fold (0.09 log units) above the measured one, within the range that was stated.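

In this assay, chloro in place of methoxy, on an aromatic carbon para to a large group, gives an at least 1.2-fold lower number from compound 1 to compound 3 (0.08 log units; that floor lies within the scatter). Among these compounds, this is the only step read at this position, and it shows that the exchange yields a measured number where the methoxy compound gives only a limit, though the printed floor of the step does not establish a change beyond the scatter. How large the step really is stays unknown because one end of it is only a limit: the limit of > 40000 nM in this assay, at which 1 of the 3 values shown sits.

The compounds shown leave open how an amine or a carboxylic acid at this same place would read, and whether any group here would move the value away from the weak end of the scale. They also leave open whether 4-methoxyphenyl to 4-chlorophenyl would give a similar step on another core.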